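The compounds below may be only part of what the source reports. "The series", "measured", "known", "first", "only" and "open" are said of these compounds alone.

The measured compounds in a functional assay on DU-145 cells (Homo sapiens) for inhibition, read by trypan blue exclusion, with a stated time of 96 h; a lower number here means a stronger inhibitor of growth, a higher number a weaker inhibitor of growth:

compound 1, `Cc1ccc(CS/C(=C/c2ccc(N(C)C)cc2)C(=O)c2ccc(Cl)cc2)cc1`: > 100000 nM, which is a limit of the assay, not a number
compound 2, `Cc1ccsc1/C=C(/SCc1ccc(Cl)cc1)C(=O)c1ccc(Cl)cc1`: 50000 nM
compound 3, `Cc1ccsc1/C=C(/SCc1ccc(Cl)c(Cl)c1)C(=O)c1ccc(Cl)cc1`: 50000 nM

Compound 3 stands level with compound 2 in this assay at the digits shown; the step of no change at the digits printed from compound 2 to compound 3 (within the scatter) lies within the scatter of the measurement. Compound 1 alone sits at the limit, as recorded in the limit of > 100000 nM in this assay, at which 1 of the 3 values shown sits.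

Compound 4, `CN(C)c1ccc(/C=C(/SCc2ccc(Cl)c(Cl)c2)C(=O)c2ccc(Cl)cc2)cc1`, is yet to be measured. It differs from compound 3 in one place: 4-(dimethylamino)phenyl in place of 3-methylthiophen-2-yl on a double-bonded chain carbon bound to a double-bonded chain carbon.

Going by the values given here, no measured step matches this exchange directly. Among the compounds with values here, the one measured step, from compound 2 to compound 3, concerns the benzyl thioether and shows no change, so it gives no guidance on the aryl group that carries the double bond. Compound 1, however, bears the same 4-(dimethylamino)phenyl group that enters in compound 4, and compound 1 gives only a limit. Compound 4 is therefore expected to sit weaker than compound 3 in this assay, likely near that limit, with the step of a 2.0-fold higher number from compound 3 to compound 4 (0.30 log units; within the scatter) expected. The estimate for compound 4 is 100000 nM, within a range of 40000 nM to 300000 nM.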

Compound 4, concentration for 50% growth inhibition: 50000 nM
The estimate for compound 4 lay 2.0-fold (0.30 log units) above the measured number; the measured number falls inside the stated range.
By their numbers in this assay, from the lowest: compounds 2, 3 and 4 (each within the scatter of the next). At a limit, above all of these: compound 1.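

In this assay, 4-(dimethylamino)phenyl in place of 3-methylthiophen-2-yl on a double-bonded chain carbon bound to a double-bonded chain carbon gives no change at the digits printed from compound 3 to compound 4 (within the scatter), so at this position the five-membered sulfur ring and the six-membered carbon ring with its dimethylamino group cannot be told apart. The 4-(dimethylamino)phenyl group therefore does not by itself tie a compound to the limit, and 3,4-dichlorophenyl in place of 4-methylphenyl on a saturated chain carbon bound to a sulfur gives an at least 2.0-fold lower number from compound 1 to compound 4 (0.30 log units; that floor lies within the scatter), a floor and not a measured size. Compound 1 remains a limit of the assay and not a number, and the real size of that step stays unknown: the limit of > 100000 nM in this assay, at which 1 of the 4 values shown sits.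

The compounds shown leave open whether any group on this double-bonded chain carbon can move the number in this assay, as both aryl groups give the same reading with the 3,4-dichlorophenyl thioether in place. They also leave open how a carboxylic acid or a morpholine ring in place of the dimethylamino group would read.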